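A few compounds are considered here, and "the series" means these few. Any claim that something is new, unique, unknown or untested is made for them only; others in the source may bear on it.

Measured in a functional assay on MIA PaCa-2 cells (Homo sapiens) for cytotoxicity, read by fluorescence, with a stated time of 48 h; on this read-out lower numbers stand for an effect already at smaller amounts and higher numbers for an effect only at larger amounts of compound:
- compound 1 `CC(C)=CCC/C(C)=C/CC/C(C)=C/CSC[C@H](NC(=O)CCCCCN1CCCC1)C(=O)NC1CCCC1`: 3200 nM
- compound 2 `CC(C)=CCC/C(C)=C/CC/C(C)=C/CSC[C@H](NC(=O)CCCCCN1CCCC1)C(=O)N1CCCCC1`: 12400 nM

Of these two numbers, the higher belongs to compound 2 at 12400 nM. Compound 3 `CC(C)=CCC/C(C)=C/CC/C(C)=C/CSC[C@H](NC(=O)CCCCCN1CCCC1)C(=O)NC1CC1` differs from it by cyclopropylamino in place of piperidin-1-yl on a carbonyl carbon, with cyclopropylamino in place of piperidin-1-yl on a carbonyl carbon. Among the measured compounds shown here, one measured step bears on this change: a 3.9-fold higher number from compound 1 to compound 2 (0.59 log units; beyond the scatter), where piperidin-1-yl took the place of cyclopentylamino. Reversing that exchange suggests a modest move towards a lower number in this assay, although cyclopropylamino itself has no measured precedent. The expected change is a 2.8-fold lower number from compound 2 to compound 3 (0.44 log units; beyond the scatter). Compound 3 is estimated at 4500 nM, with an expected range of 1800 nM to 11000 nM.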

Compound 3, half-maximal effective concentration: > 20000 nM
Compound 3 was reported as a limit; the forecaster's own chance of this, stated with the estimate: 3%; middle value at least 4.4-fold (0.64 log units) from the limit.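

In this assay the reading for compound 3 is a limit and not a number: the limit of > 20000 nM in this assay, at which 1 of the 3 values shown sits. Cyclopropyl in place of cyclopentyl on the amide-type nitrogen gives an at least 6.2-fold higher number from compound 1 to compound 3 (0.79 log units; beyond the scatter), so keeping the amide hydrogen does not by itself preserve the lower number of compound 1. Cyclopropylamino in place of piperidin-1-yl gives an at least 1.6-fold higher number from compound 2 to compound 3 (0.20 log units; that floor lies within the scatter), and this leaves the order of those two compounds unsettled.

Going by these compounds, whether the number follows ring size on this carbonyl carbon remains open. Cyclobutylamino or cyclohexylamino would bear on that question.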